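A few compounds are considered here, and "the series" means these few. Any claim that something is new, unique, unknown or untested is made for them only; others in the source may bear on it.

The series shares one core; compound 1 `COc1cc(N)c(Cl)cc1NC(=O)C1CCN(CC2CCCCC2)CC1` carries cyclohexyl, compound 2 `COc1cc(N)c(Cl)cc1NC(=O)C1CCN(CC2CCCC2)CC1` cyclopentyl and compound 3 `COc1cc(N)c(Cl)cc1NC(=O)C1CCN(Cc2ccccc2F)CC1` 2-fluorophenyl, each on a saturated chain carbon bound to an amine nitrogen in a ring. In a functional assay on the whole organism for antagonist activity, with Mus musculus as the target (on this read-out lower numbers stand for an effect already at smaller amounts and higher numbers for an effect only at larger amounts of compound), compound 1 gives 2.9 mg/kg. Compound 2 returns only a limit in this assay, > 10 mg/kg. Compound 3 likewise returns a limit in this assay, > 4 mg/kg. Compound 2 thus stands at the highest number shown, and that number is a limit, not a measured value. Compound 4 `COc1cccc(CN2CCC(C(=O)Nc3cc(Cl)c(N)cc3OC)CC2)c1` is not yet measured; it differs from compound 2 by 3-methoxyphenyl in place of cyclopentyl on a saturated chain carbon bound to an amine nitrogen in a ring. Of the measured steps, an at least 3.4-fold higher number from compound 1 to compound 2 (0.53 log units; beyond the scatter) is the move to cyclopentyl, an at least 1.3-fold higher number from compound 1 to compound 3 (0.13 log units; that floor lies within the scatter) is the move to an aromatic ring with a floor within the scatter, and a step that the two limits leave unreadable from compound 2 to compound 3 cannot be read. An aromatic ring entering in place of cyclopentyl is therefore expected to bring the number back toward the region of compound 1 and compound 3, a step of an at least 2.0-fold lower number from compound 2 to compound 4 (0.30 log units; that floor lies within the scatter) expected in this assay. Compound 4 is estimated at 5 mg/kg, between 1.5 mg/kg and 15 mg/kg, with a real chance that only a limit is reported.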

Compound 4, dose for half-maximal effect: > 4 mg/kg
Compound 4 ended at the assay's limit; the forecaster's own chance of this, stated with the estimate: 50%; the middle value does not contradict the limit.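

In this assay compound 4 returns only a limit, > 4 mg/kg, so 3-methoxyphenyl, like 2-fluorophenyl, gives no measured number at this position. The comparison with cyclohexyl gives an at least 1.3-fold higher number from compound 1 to compound 4 (0.13 log units; that floor lies within the scatter), so this change is not separated from compound 1, while the steps to compound 4 from compound 2 and from compound 3 cannot be read. Two different aromatic groups, one carrying fluorine and one carrying methoxy, now end at the same limit: the limit of > 4 mg/kg in this assay, at which 2 of the 4 values shown sit.

On these data alone, how far compound 3 and compound 4 actually lie from compound 1 remains open, as does any ranking of the two aromatic groups against each other. Also open, as far as these compounds go, is whether an unsubstituted phenyl or a cycloheptyl at this place would return a number rather than a limit.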